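A few compounds are considered here, and "the series" means these few. Any claim that something is new, unique, unknown or untested is made for them only; others in the source may bear on it.

Measured compounds:
compound 1 `N=C(N)c1ccc(OCc2ccc([N+](=O)[O-])cc2)c(I)c1` — 10700000 nM
compound 2 `N=C(N)c1cccc(COc2cccc([N+](=O)[O-])c2)c1` — 104000000 nM
compound 3 `N=C(N)c1ccc(COc2ccc(C(=N)N)cc2I)cc1` — 5300000 nM

All three were read in an ADME assay on L6 cells (Rattus norvegicus) for cytotoxicity, read by resazurin assay, with a stated time of 72 h; a lower number here means a stronger inhibitor, a higher number a weaker inhibitor. Compound 2 stands highest of the three in this assay; next to it is compound 1, and furthest from it is compound 3. From compound 1 to compound 3 the nitro is exchanged for the amidine-type group, (a group of 3 heavy atoms (1 carbon, 2 nitrogen; no ring) in place of a group of 3 heavy atoms (1 nitrogen, 2 oxygen; no ring), on an aromatic carbon), and the step is a 2.0-fold lower number from compound 1 to compound 3 (0.31 log units; beyond the scatter).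

Compound 4 `N=C(N)c1cccc(COc2cccc(C(=N)N)c2)c1` carries the same kind of change on the core of compound 2: a group of 3 heavy atoms (1 carbon, 2 nitrogen; no ring) in place of a group of 3 heavy atoms (1 nitrogen, 2 oxygen; no ring), on an aromatic carbon. The place differs in one respect: in compound 3 the entering group sits para to a large group, in compound 4 it sits meta to a large group. How the core of compound 2 differs from the core of compound 1 is not broken down here.

Because a 2.0-fold lower number from compound 1 to compound 3 (0.31 log units; beyond the scatter) was only modest and the change in compound 4 is of the same kind, a step of about that size is expected in this assay: a 2.0-fold lower number from compound 2 to compound 4 (0.30 log units; within the scatter). The expectation rests on one pair only, so the range is kept wide. Compound 4 is thus expected at 52000000 nM, between 22000000 nM and 120000000 nM.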

Compound 4, half-maximal inhibitory concentration: 24000000 nM
Estimate against measurement, compound 4: 2.2-fold (0.34 log units) above; measured number inside the range.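

In this assay the step of a 4.3-fold lower number from compound 2 to compound 4 (0.64 log units; beyond the scatter) comes from exchanging the nitro for the amidine-type group on the core of compound 2, and it runs in the same direction as the step on the core of compound 1. Set side by side, the two steps cannot be told apart in size: the same change on two cores in this assay, a 2.0-fold lower number (0.31 log units; beyond the scatter) from compound 1 to compound 3 and a 4.3-fold lower number (0.64 log units; beyond the scatter) from compound 2 to compound 4, 2.1-fold (0.33 log units) apart, within the scatter of two such steps. The change therefore carries over between these two cores in direction and, within the scatter, in size, but two pairs do not show that it would hold on a third core, and they give no reason for the lower number.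

The compounds shown leave open whether another group in the same place, such as an amine, a carboxylic acid or a nitrile, would shift the number in the same way. They also do not separate the part played by the iodine of compound 1 and compound 3 from the part played by the different placement of the groups on the core of compound 2.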